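Iodo to trifluoromethyl: notes on compound 3

A few compounds are considered here, and "the series" means these few. Any claim that something is new, unique, unknown or untested is made for them only; others in the source may bear on it.

In a functional assay on HepG2 cells (Homo sapiens) for inhibition, read by MTT assay (on this read-out higher numbers stand for weaker inhibition and lower numbers for stronger inhibition), compound 1 (`COc1cc2ncnc(Nc3ccc(NC(=O)c4ccc(C(C)(C)C)cc4)cc3)c2cc1OC`) reads > 100000 nM, which is a limit of the assay and not a number. For the measured compounds named here, compound 2 (`COc1cc2ncnc(Nc3ccc(NC(=O)c4cccc(I)c4)cc3)c2cc1OC`) gives 28000 nM, the only true number so far. Compound 3 (`COc1cc2ncnc(Nc3ccc(NC(=O)c4cccc(C(F)(F)F)c4)cc3)c2cc1OC`) carries trifluoromethyl in place of iodo on an aromatic carbon, meta to a large group (trifluoromethyl in place of iodo on an aromatic carbon). Going by the values given here, one measured step bears on this change, and it lies beyond the scatter: an at least 3.5-fold lower number from compound 1 to compound 2 (0.55 log units; beyond the scatter). That step swapped 4-(tert-butyl)phenyl for 3-iodophenyl, so it involves a different pair of groups and gives only a loose guide to size. Among the compounds with values here, with no measured step for this exact swap, no clear shift in this assay is expected, and the expected step of a 1.3-fold higher number from compound 2 to compound 3 (0.10 log units; within the scatter) stays within the scatter. Compound 3 is estimated at 35000 nM, with an expected range of 10000 nM to 100000 nM.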

Compound 3, half-maximal inhibitory concentration: 83000 nM
The estimate for compound 3 lay 2.4-fold (0.38 log units) below the measured number; the measured number falls inside the stated range.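

The read-out in this assay responds to the group at this place on the aromatic ring: trifluoromethyl in place of iodo gives a step with true numbers at both ends (a 3.0-fold higher number from compound 2 to compound 3 (0.47 log units; beyond the scatter)). Compound 1 reads > 100000 nM as a limit of the assay and not a number. The comparison with 3-(trifluoromethyl)phenyl therefore yields only a floor (an at least 1.2-fold lower number from compound 1 to compound 3 (0.08 log units; that floor lies within the scatter)), and its true size cannot be read: the limit of > 100000 nM in this assay, at which 1 of the 3 values shown sits.

The compounds shown leave open whether a chloro, a nitrile or an amine at this place would give a lower number than iodo does. For the compounds shown here, with only one pair carrying this swap, no trend across groups at this place can yet be drawn.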